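Lengthening the alkyl chain on the shared core

A few compounds are considered here, and "the series" means these few. Any claim that something is new, unique, unknown or untested is made for them only; others in the source may bear on it.

Measured compounds:
compound 1 `CC1(C)C(=O)Nc2nc(-n3nc(Cc4ccccc4F)c4cc(Cl)ccc43)nc(N)c21` gives 18000 nM
compound 2 `CC1(C)C(=O)Nc2nc(-n3nc(Cc4c(F)ccc(F)c4F)c4cc(Cl)ccc43)nc(N)c21` gives 7300 nM
compound 3 `CCCc1nn(-c2nc(N)c3c(n2)NC(=O)C3(C)C)c2ccc(Cl)cc12` gives 546000 nM

In an assay on CHO cells for activation of soluble guanylate cyclase alpha1/beta1 complex (Homo sapiens), read by cGMP accumulation (on this read-out lower numbers stand for an effect already at smaller amounts and higher numbers for an effect only at larger amounts of compound), compound 3 stands at the highest number of the three, with a 30-fold higher number from compound 1 to compound 3 (1.48 log units; beyond the scatter) and a 75-fold higher number from compound 2 to compound 3 (1.87 log units; beyond the scatter) separating it from the two compounds that carry a fluorinated ring on the saturated chain carbon bound to an aromatic carbon. Compound 4 `CCCCCc1nn(-c2nc(N)c3c(n2)NC(=O)C3(C)C)c2ccc(Cl)cc12` differs from compound 3 only by ethyl in place of hydrogen on a saturated chain carbon, three bonds along the chain from an aromatic carbon. Among the measured compounds shown here, no measured pair shows a chain being lengthened in this way; the two steps that reach compound 3 only show what is lost when an aromatic ring gives way to ethyl, and adding ethyl further along the chain brings no ring back. The expectation for this assay is therefore a step of a 1.4-fold lower number from compound 3 to compound 4 (0.14 log units; within the scatter), which stays within the usual scatter, and compound 4 is estimated at 400000 nM with a range from 120000 nM to 1300000 nM.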

Compound 4, half-maximal effective concentration: 90000 nM
For compound 4 the middle estimate is 4.4-fold (0.65 log units) above the measured one; measured number below the stated range.
By their numbers in this assay, from the lowest: compound 2; then compound 1; then compound 4; then compound 3.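

In this assay the length of the chain matters at this position: ethyl in place of hydrogen on a saturated chain carbon, three bonds along the chain from an aromatic carbon, gives a 6.1-fold lower number from compound 3 to compound 4 (0.78 log units; beyond the scatter) and is the first change shown that adds only saturated carbon. Butyl still does not match either fluorinated ring on the saturated chain carbon bound to an aromatic carbon, since replacing the rings gives a 12-fold higher number from compound 2 to compound 4 (1.09 log units; beyond the scatter) for the trifluorophenyl compound and a 5.0-fold higher number from compound 1 to compound 4 (0.70 log units; beyond the scatter) for the fluorophenyl compound. The longer chain thus closes only part of the gap between compound 3 and the two ring compounds.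

Nothing available explains the gain from the longer chain. From the compounds shown here alone, whether a longer chain such as heptyl, or a chain carrying an amine, would lower the number further remains open.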